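The compounds below may be only part of what the source reports. "The series", "measured", "known", "first", "only" and "open" are said of these compounds alone.

Of the compounds shown here, three with a shared core have been measured in an assay on isolated protein for inhibition of proto-oncogene tyrosine-protein kinase receptor Ret (Homo sapiens), read by radiometric assay and 33P incorporation, in the presence of a further agent that is not named here; a higher number here means a weaker inhibitor, a lower number a stronger inhibitor. Compound 1 `CC(C)n1nc(-c2cc(C3CCCCC3)on2)c2c(N)ncnc21` gives 910 nM. Compound 2 `Nc1ncnc2c1c(-c1cc(C3CC3)on1)nn2C1CCCCC1` gives 2 nM, and compound 3 `Cn1nc(-c2cc(C3CC3)on2)c2c(N)ncnc21` gives 27 nM. Compound 1 therefore stands highest of the three, far above compound 3 and further still above compound 2.

For the measured compounds named here, the one measured pair that differs in a single place is compound 2 to compound 3, where the change is a 14-fold higher number from compound 2 to compound 3 (1.13 log units; beyond the scatter). That change sits on the aromatic nitrogen, a different place from the one now in question.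

Compound 4 `CCc1cc(-c2nn(C(C)C)c3ncnc(N)c23)no1` differs from compound 1 by ethyl in place of cyclohexyl on an aromatic carbon. Going by the values given here, no measured pair changes only this group, so the bearing of the known steps is indirect. Both compound 2 and compound 3 carry a small group at this position and give far lower numbers than compound 1, yet they also differ from compound 1 at the aromatic nitrogen. A lower number is expected for compound 4, a step of a 15-fold lower number from compound 1 to compound 4 (1.18 log units; beyond the scatter). The estimate for compound 4 is 60 nM, within 10 nM to 300 nM.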

Compound 4, half-maximal inhibitory concentration: 41 nM
Compound 4: middle estimate off by 1.5-fold (0.17 log units), on the high side; the measured number falls inside the stated range.
By their numbers in this assay, from the lowest: compound 2; then compounds 3 and 4 (each within the scatter of the next); then compound 1.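

For the compounds shown here, until now, the only change read in isolation sat on the aromatic nitrogen. Here the group on the aromatic carbon next to the ring oxygen changes alone, and in this assay replacing cyclohexyl with ethyl gives a 22-fold lower number from compound 1 to compound 4 (1.35 log units; beyond the scatter), so this position on its own can shift the number by a large amount, with the rest of the molecule unchanged. Nothing available accounts for the size of this step.

Going by these compounds, only cyclohexyl and ethyl form a matched pair at this carbon, so it remains open how a methyl group or a longer chain such as butyl would read there. Also open, on these data alone, is whether an amine or a carboxylic acid on this carbon would keep the number low, and whether the step would keep its size with cyclohexyl on the aromatic nitrogen.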